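The compounds below may be only part of what the source reports. "The series", "measured", "known", "first", "only" and "open" are said of these compounds alone.

In a functional assay for activation of Alpha-1D adrenergic receptor (Homo sapiens) (a lower number here means that less compound is needed, a higher number that more compound is needed for the effect), compound 2 `c1ccc(-c2ccccc2NCC2=NCCN2)nc1` gives 41.7 nM, and compound 3 `c1ccc(-c2cnccn2)c(NCC2=NCCN2)c1` gives 182 nM. Compound 1 `Cc1nc(-c2ccccc2NCC2=NCCN2)co1` gives only a limit of the assay, < 5020 nM. For that reason the steps a step that the limit leaves unreadable from compound 1 to compound 2 and a step that the limit leaves unreadable from compound 1 to compound 3 cannot be sized. Of the two numbers actually read, compound 3 has the highest, with compound 2 nearest: a 4.4-fold higher number from compound 2 to compound 3 (0.64 log units; beyond the scatter). Compound 4 `CO/N=C/c1ccccc1NCC1=NCCN1` differs from compound 3 in one place: a group of 4 heavy atoms (2 carbon, 1 nitrogen, 1 oxygen; no ring) in place of a group of 6 heavy atoms (4 carbon, 2 nitrogen; one six-membered aromatic ring with 2 hetero atoms), on an aromatic carbon. Among the measured compounds shown here, no measured step exchanges a ring for an open chain; the only sized step, a 4.4-fold higher number from compound 2 to compound 3 (0.64 log units; beyond the scatter), shows that a change of roughly this extent moved the number modestly. Expected, then, is a modest step, a 1.6-fold higher number from compound 3 to compound 4 (0.22 log units; within the scatter), with the direction uncertain. Compound 4 is estimated at 300 nM, within a range from 80 nM to 1200 nM.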

Compound 4, half-maximal effective concentration: < 5020 nM
Compound 4 ended at the assay's limit; the forecaster's own chance of this, stated with the estimate: 10%; the middle value lies beyond the limit too.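

In this assay compound 4 gives only a limit, < 5020 nM, so its steps from compound 1, compound 2 and compound 3 cannot be read. The compounds shown leave open how far compound 4 actually lies from compound 2 and compound 3.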